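The source may hold more compounds than are shown below. What is called first, only, known or untested is meant among the compounds shown, and "the series" means these compounds.

Working notes on the series. Compound 2 `COc1ccc(-c2nc(C)c(C(=O)CSc3nc(N)c(C#N)c(-c4ccc(OC)cc4)n3)s2)cc1` stands lowest of the two numbers measured in a functional assay on U-87MG ATCC cells for antiproliferative activity against U-87 MG (Homo sapiens), read by MTT assay, with a stated time of 48 h, tested at 10 uM; a lower number here means a stronger effect, a higher number a weaker effect of the compound at the concentration tested: compound 2 gives 28.7%, while compound 1 `COc1ccc(-c2nc(C)c(C(=O)CSc3nc(N)c(C#N)c(-c4ccccc4)n3)s2)cc1` gives 57.8%. Among the measured compounds shown here, the one measured step, a number 29.1 percentage points lower from compound 1 to compound 2 (beyond the scatter), came with methoxy in place of hydrogen on an aromatic carbon and was modest but beyond the scatter. Compound 3 `COc1ccc(-c2nc(SCC(=O)c3sc(-c4ccc(Cl)cc4)nc3C)nc(N)c2C#N)cc1` is not yet measured; it differs from compound 2 by chloro in place of methoxy on an aromatic carbon. For the measured compounds named here, no measured step exchanges chloro for methoxy, so the step from compound 2 to compound 3 rests on one indirect piece of evidence: the methoxy on that ring carried the drop seen in compound 2, and its removal points back toward the number of compound 1, with the chloro of unknown weight. A step of uncertain direction is expected, a number 13.3 percentage points higher from compound 2 to compound 3 (beyond the scatter), likely toward a weaker effect. Compound 3 is estimated at 42% in this assay, within 22% to 62%.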

Compound 3, a percentage reported as activity, at one concentration (the size of the read-out at that concentration, not a potency): 64.5%
Compound 3: the middle estimate sits 22.5 percentage points below what was measured, outside the stated range (above it).
By their numbers in this assay, from the lowest: compound 2; then compounds 1 and 3 (each within the scatter of the next).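

In this assay, the exchange of 4-methoxyphenyl for 4-chlorophenyl gives a number 35.8 percentage points higher from compound 2 to compound 3 (beyond the scatter), a large step toward a weaker effect. This change sits on the other 4-methoxyphenyl group of compound 2, not on the aryl group that carried a number 29.1 percentage points lower from compound 1 to compound 2 (beyond the scatter), so the series now shows a second aromatic position where the group para to a large group matters. No measured property bears on this step.

The compounds shown leave open whether the step follows from losing the methoxy or from gaining the chloro. Plain hydrogen, an amine or a carboxylic acid at this same place would separate those two readings and show how far this position tolerates other groups.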